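The source may hold more compounds than are shown below. What is called first, only, known or untested is meant among the compounds shown, and "the series" means these compounds.

Working notes on the series. Two compounds sharing one core have been run in an assay on cells for activation of Cystic fibrosis transmembrane conductance regulator (Homo sapiens), read by fluorescence, with stated times of 10 min and 12 s; on this read-out lower numbers stand for an effect already at smaller amounts and higher numbers for an effect only at larger amounts of compound. Within the data shown here, compound 1 `CCN(CC)c1nc(Nc2cccc(F)c2)nc(OC(C(F)(F)F)C(F)(F)F)n1` gives 140 nM, the lowest of the two numbers so far. Compound 2 `CCN(CC)c1nc(Nc2ccc(F)cc2)nc(OC(C(F)(F)F)C(F)(F)F)n1` gives 700 nM, which is a 5.0-fold higher number from compound 1 to compound 2 (0.70 log units; beyond the scatter). That single step is the only one available and it concerns the placing of the fluorine on the phenyl ring attached to the ring nitrogen; it carries no direct information on a fused bicyclic replacement.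

Compound 3 `CCN(CC)c1nc(Nc2ccc3cn[nH]c3c2)nc(OC(C(F)(F)F)C(F)(F)F)n1` differs from compound 1 in one place: 1H-indazol-6-yl in place of 3-fluorophenyl on a nitrogen on an aromatic ring. Among the measured compounds shown here, the series holds no measured analogue with a fused ring or a hydrogen-bond donor at this position, so the expectation rests on the sensitivity already seen with compound 2 and is correspondingly loose. A step of about a 2.1-fold higher number from compound 1 to compound 3 (0.33 log units; beyond the scatter) is expected, with either direction left open. Compound 3 is estimated at 300 nM, with a range from 60 nM to 1500 nM.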

Compound 3, half-maximal effective concentration: 900 nM
The estimate for compound 3 lay 3.0-fold (0.48 log units) below the measured number; low and high end bracket the measured number.
By their numbers in this assay, from the lowest: compound 1; then compounds 2 and 3 (each within the scatter of the next).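

Notes on the (1H-indazol-6-yl)amino result: in this assay, replacing 3-fluorophenyl on this nitrogen with the fused 1H-indazol-6-yl gives a 6.4-fold higher number from compound 1 to compound 3 (0.81 log units; beyond the scatter) and so does not retain the level of compound 1. Set against 4-fluorophenyl, the same group gives a 1.3-fold higher number from compound 2 to compound 3 (0.11 log units; within the scatter) and cannot be separated from it, so two groups of different ring make-up read alike here and, among the three compounds, only 3-fluorophenyl stands apart. Nothing available bears on the cause of either step.

Whether the fused ring or the ring nitrogens of 1H-indazol-6-yl account for the step from 3-fluorophenyl remains open. Also open, going by these compounds, is how this nitrogen would read with 3-chlorophenyl, 3-methoxyphenyl or a phenyl ring carrying a carboxylic acid.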